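The source may report more compounds than this note shows. Statements on the series, on what has been measured and on what is new or still open speak of the compounds shown alone.

Working notes on the series. In a functional assay on HT-29 cells (Homo sapiens) for cytotoxicity, read by MTT assay (on this read-out higher numbers stand for weaker inhibition and lower numbers for stronger inhibition), compound 1 (`C=C1C(=O)[C@]23C[C@@]1(Cl)CC[C@H]2[C@@]12C=CC(=O)[C@](C)(C(=O)O1)[C@H]2[C@@H]3C(=O)OCc1ccccc1`) gives 4500 nM as its half-maximal inhibitory concentration. Compound 2 (`C=C1C(=O)[C@]23C[C@@]1(O)CC[C@H]2[C@@]12C=CC(=O)[C@](C)(C(=O)O1)[C@H]2[C@@H]3C(=O)OC`) gives 65700 nM and holds the higher of the two numbers, with a gap to compound 1 that lies beyond the scatter. These two compounds differ in more than one place, so the gap is not a single-change step.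

Compound 3 (`C=C1C(=O)[C@]23C[C@@]1(O)CC[C@H]2[C@@]12C=CC(=O)[C@](C)(C(=O)O1)[C@H]2[C@@H]3C(=O)OCc1ccccc1`) comes from compound 2 by one change: phenyl in place of hydrogen on a saturated chain carbon bound to an oxygen next to a carbonyl group and this places phenyl in place of hydrogen on a saturated chain carbon bound to an oxygen next to a carbonyl group, so that methoxycarbonyl becomes benzyloxycarbonyl. Among the measured compounds shown here, no measured pair isolates this change. For the measured compounds named here, the only hint is compound 1, which also carries benzyloxycarbonyl and gives 4500 nM against the higher number of compound 2. On these data alone, how much of that gap belongs to this change is unknown, so a move in this assay toward a lower number, smaller than the whole gap, is expected. The expected move is a 4.4-fold lower number from compound 2 to compound 3 (0.64 log units; beyond the scatter) and it would probably lie beyond the scatter. For compound 3 the estimated value is 15000 nM with an expected range from 5000 nM to 50000 nM in this assay.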

Compound 3, half-maximal inhibitory concentration: 83300 nM
Compound 3: the middle estimate sits 5.6-fold (0.74 log units) below what was measured; the whole stated range lies below it.
By their numbers in this assay, from the lowest: compound 1; then compounds 2 and 3 (each within the scatter of the next).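

Working notes, continued. In this assay, phenyl in place of hydrogen on a saturated chain carbon bound to an oxygen next to a carbonyl group gives a 1.3-fold higher number from compound 2 to compound 3 (0.10 log units; within the scatter), so with hydroxy held on the saturated ring carbon, methoxycarbonyl and benzyloxycarbonyl are not told apart by this read-out. Among the compounds shown here, with benzyloxycarbonyl held instead, hydroxy in place of chloro on a saturated ring carbon gives a 19-fold higher number from compound 1 to compound 3 (1.27 log units; beyond the scatter), which places the one large single-change step in these compounds at the ring carbon and not at the chain carbon. Nothing available accounts for either step.

The compounds shown leave open whether the low number of compound 1 is particular to chloro or would also appear with fluoro, bromo or an amine on that saturated ring carbon. They also leave open whether methoxycarbonyl and benzyloxycarbonyl would still read alike with chloro on the ring carbon, and how a carboxylic acid or a longer chain such as butoxycarbonyl would read in their place.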